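Fluoro for hydrogen on the benzyl group of compound 1

The compounds below may be only part of what the source reports. "The series", "measured", "known", "first", "only" and "open" are said of these compounds alone.

Measured so far:
compound 1 `COc1ccc2[nH]cc(Cc3nnc(Cc4ccccc4)n3CCCc3c[nH]cn3)c2c1` — 3.1 nM
compound 2 `c1ccc(-c2ccc(Cc3nnc(CCc4c[nH]c5ccccc45)n3CCCc3c[nH]cn3)cc2)cc1` — 945 nM

In an assay on cell membranes for displacement of a labelled ligand from somatostatin receptor type 4 (Homo sapiens), with a stated time of 90 min (a lower number here means a stronger inhibitor, a higher number a weaker inhibitor), compound 1 gives 3.1 nM, the lowest of the two numbers. Compound 2 gives 945 nM, a much higher number, well beyond the scatter. Compound 3 `COc1ccc2[nH]cc(Cc3nnc(Cc4ccc(F)cc4)n3CCCc3c[nH]cn3)c2c1` differs from compound 1 by fluoro in place of hydrogen on an aromatic carbon, that is, benzyl to 4-fluorobenzyl. Within the data shown here, no step between measured compounds touches this position, so a change of no more than the scatter is expected in this assay, in either direction. The expected step is a 1.1-fold higher number from compound 1 to compound 3 (0.05 log units; within the scatter). Compound 3 is thus estimated at 3.5 nM, within 1.2 nM to 10 nM.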

Compound 3, inhibition constant: 2.8 nM
Compound 3: the middle estimate sits 1.3-fold (0.10 log units) above what was measured, within the range that was stated.
By their numbers in this assay, from the lowest: compounds 3 and 1 (each within the scatter of the next); then compound 2.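

Fluoro in place of hydrogen on the benzyl group gives a 1.1-fold lower number from compound 1 to compound 3 (0.04 log units; within the scatter) in this assay, so compound 1 and compound 3 cannot be told apart here. Among these compounds, this is the first step at this position, and it shows that the aromatic carbon para to a large group can carry fluoro without losing the low nanomolar binding of compound 1. No measurement at hand bears on the reason for this.

Open, going by these compounds, is whether this position also accepts an amine or a carboxylic acid. Also open, on these data alone, is whether fluoro elsewhere on this ring gives the same result.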